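A few compounds are considered here, and "the series" means these few. Any claim that something is new, unique, unknown or untested is made for them only; others in the source may bear on it.

Working notes on the series. Compound 2 `Cc1ncc(-c2cc(NC(=O)c3ccc(OCc4ccccn4)cc3)c(C)cc2C)[nH]1` sits, in a physicochemical assay for lipophilicity (a higher number here means a more lipophilic compound, a lower number a more polar compound), at 2.8; compound 3 `Cc1ccc(-c2ncc[nH]2)c(C)c1NC(=O)c1ccc(OCc2ccccn2)cc1` gives 2.8, level with compound 2 at the digits shown, and compound 1 `Cc1cc(C)c(-c2ncc[nH]2)cc1NC(=O)c1ccc(OCc2ccccn2)cc1` gives 3.1. Within the data shown here, the only step measured so far is a number 0.30 log units lower from compound 1 to compound 2 (within the scatter), a move at the same ring position. Compound 4 `Cc1cc(C)c(-c2c[nH]nc2C)cc1NC(=O)c1ccc(OCc2ccccn2)cc1` differs from compound 2 only by 3-methyl-1H-pyrazol-4-yl in place of 2-methyl-1H-imidazol-5-yl on an aromatic carbon. Among the measured compounds shown here, compound 3 has no measured step to either of these. For the measured compounds named here, the one measured change of the five-membered ring stayed within the scatter, so no movement beyond it is expected here either. The estimate for compound 4 in this assay is 3, range 2.5 to 3.5, a step of a number 0.20 log units higher from compound 2 to compound 4 (within the scatter) expected from compound 2 to compound 4.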

Compound 4, distribution coefficient: > 3
Compound 4 gave a limit, no number; the forecaster's own chance of this, stated with the estimate: 2%; the middle value sits exactly at the limit.
By their numbers in this assay, from the lowest: compounds 2, 3 and 1 (each within the scatter of the next).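

In this assay compound 4 gives > 3, a limit and not a number: the limit of > 3 in this assay, at which 1 of the 4 values shown sits. On this aromatic carbon, 3-methyl-1H-pyrazol-4-yl in place of 2-methyl-1H-imidazol-5-yl keeps the same counted atoms, donor and acceptor, and gives a number at least 0.20 log units higher from compound 2 to compound 4 (that floor lies within the scatter), so the true size of this change has a floor but no upper bound. The step from compound 1 to compound 4 cannot be read.

As far as these compounds go, the actual value of compound 4 remains open. So does the effect of an amine or a carboxylic acid at this position in place of the five-membered ring.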